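Alkynyl quinolone series: solubility notes toward compound 4

The source may report more compounds than this note shows. Statements on the series, on what has been measured and on what is new or still open speak of the compounds shown alone.

Measured so far in a physicochemical assay for solubility, read by HPLC, at pH 7.4; a higher number here means a more soluble compound, a lower number a less soluble compound:
Compound 1, `C=C(CCCCCCC)c1c(C)[nH]c2ccccc2c1=O`, gives < 2000 nM, a limit of this assay rather than a number.
Compound 2, `CCCCC#Cc1c(C)[nH]c2ccc(Cl)cc2c1=O`, gives 2000 nM.
Compound 3, `CCCCC#Cc1c(C)[nH]c2ccc(F)cc2c1=O`, gives 2000 nM.

Compound 2 stands level with compound 3 at the digits shown; the single measured step, no change at the digits printed from compound 2 to compound 3 (within the scatter), lies within the scatter. Compound 1 offers only a limit, (the limit of < 2000 nM in this assay, at which 1 of the 3 values shown sits), and cannot be ranked against the other two.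

The next compound, compound 4, `CCCCC#Cc1c(C)[nH]c2cc(OC)c(Cl)cc2c1=O`, differs from compound 2 by methoxy in place of hydrogen on an aromatic carbon. Within the data shown here, no measured step involves a methoxy group or any change at that aromatic carbon, so the halogen swap between compound 2 and compound 3 bears on it only indirectly, showing that a single substituent change on that ring left this assay unchanged. Without closer precedent, the step is expected to be small, with no firm direction: the estimated step is a 1.5-fold higher number from compound 2 to compound 4 (0.18 log units; within the scatter). Compound 4 is therefore expected near 3000 nM, within 1000 nM to 9000 nM.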

Compound 4, solubility: > 20000 nM
Compound 4: no number, only a limit; the forecaster's own chance of this, stated with the estimate: 30%; middle value at least 6.6-fold (0.82 log units) away from the limit.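

In this assay, methoxy in place of hydrogen on this aromatic carbon, ortho to a chloro group, gives an at least 10-fold higher number from compound 2 to compound 4 (1.00 log units; beyond the scatter). The fluoro for chloro swap gave no change at the digits printed from compound 2 to compound 3 (within the scatter), whereas this step shows that a single change on the ring can move the reading beyond the scatter. Compound 4 gives only a limit of the assay, not a number, so the full size of the step cannot be read: the limit of > 20000 nM in this assay, at which 1 of the 4 values shown sits.

The compounds shown do not separate methoxy itself from substitution at this carbon in general; a hydroxyl group, an amine or a longer ether at the same place would bear on that. They also leave open whether the step would carry over with fluoro in place of chloro on the ring.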